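The source may hold more compounds than are shown below. What is called first, only, known or untested is meant among the compounds shown, and "the series" means these compounds.

In an ADME assay on HEK293 cells (Homo sapiens) for cytotoxicity, read by resazurin assay, with a stated time of 72 h (a higher number here means that more compound is tolerated, a lower number that less compound is tolerated), compound 1 (`O=C(O)c1ccc(CCOc2c(F)ccc3nc(C(=O)NCc4ccccc4)[nH]c(=O)c23)cc1`) gives > 20000 nM, which is a limit of the assay and not a number. Compound 2 (`O=C(O)c1ccc(CCOc2c(F)ccc3nc(C(=O)NCc4cccc(C5CC5)c4)[nH]c(=O)c23)cc1`) gives > 20000 nM, again a limit and not a number. Compound 2 therefore stands with compound 1 at the limit of > 20000 nM in this assay, at which 2 of the 2 values shown sit. Compound 3 (`CCc1cccc(CNC(=O)c2nc3ccc(F)c(OCCc4ccc(C(=O)O)cc4)c3c(=O)[nH]2)c1`) differs from compound 2 by ethyl in place of cyclopropyl on an aromatic carbon, meta to a large group. For the measured compounds named here, the only measured step that bears on this change is a step that the two limits leave unreadable from compound 1 to compound 2, so it offers no size to carry over. No step beyond the scatter is therefore expected in this assay, in either direction. The estimate amounts to a step that the limit leaves unreadable from compound 2 to compound 3, an expected step with no direction to it. For compound 3 the expected value is 25000 nM, with an expected range from 12000 nM to 50000 nM.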

Compound 3, half-maximal cytotoxic concentration: > 20000 nM
Compound 3 was reported as a limit (the forecaster's own chance of this, stated with the estimate: 85%); the middle value lies beyond the limit too.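

In this assay no step can be read among compound 1, compound 2 and compound 3, since all three stand at a limit and not at a number: the limit of > 20000 nM in this assay, at which 3 of the 3 values shown sit.

The compounds shown leave open whether hydrogen, cyclopropyl or ethyl on that aromatic carbon makes any difference to the concentration tolerated.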